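This account rests on a few compounds, and the source may have more. Where it says the series, first, only, none or still open, it means among the compounds named here.

Three compounds share one core. Compound 1 is `COc1cc(=O)n(C)cc1-c1ccnc2[nH]c(C3CCN(CC(=O)N(C)C)CC3)cc12`, compound 2 is `CN(C)C(=O)CN1CCC(c2cc3c(-c4ccc(=O)n(C5CCC5)c4)ccnc3[nH]2)CC1` and compound 3, not yet measured, is `CN(C)C(=O)CN1CCC(c2cc3c(-c4ccc(=O)n(C)c4)ccnc3[nH]2)CC1`. In an ADME assay on cells (Hepatocyte, Rattus norvegicus) for metabolic stability (on this read-out higher numbers stand for fast clearance and lower numbers for slow clearance), compound 1 reaches only a limit of the assay, < 1 uL/min, and no number is obtained for it. In this assay compound 2 gives 5.8 uL/min. Within the data shown here, compound 2 therefore holds the only number among the two measured values, the other being a limit (the limit of < 1 uL/min in this assay, at which 1 of the 2 values shown sits). Between compound 1 and compound 2 no single-change step is drawn, so nothing more can be read from their pair than what the two values show.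

Compound 3 differs from compound 2 in one place: methyl in place of cyclobutyl on an aromatic nitrogen. The step from compound 2 to compound 3 is expected to move the read-out downward by a moderate amount, a 2.3-fold lower number from compound 2 to compound 3 (0.37 log units; beyond the scatter), somewhat beyond the usual scatter. In this assay compound 3 is accordingly expected to give about 2.5 uL/min, with a range from 1 uL/min to 6 uL/min.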

Compound 3, intrinsic clearance in a liver preparation (reported as CLH), per the amount of preparation that the assay uses in the Hepatocyte assay: < 1 uL/min
Compound 3: a limit, no number (the forecaster's own chance of this, stated with the estimate: 30%); middle value at least 2.5-fold (0.39 log units) away from the limit.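

Among these compounds, in the Hepatocyte assay, methyl in place of cyclobutyl on the aromatic nitrogen gives an at least 5.8-fold lower number from compound 2 to compound 3 (0.76 log units; beyond the scatter), so this position affects the read-out, and the cyclobutyl compound is the one of this pair with a number. In a physicochemical assay for solubility, in phosphate buffer, at pH 7.4 (on this read-out higher numbers stand for higher solubility and lower numbers for lower solubility), compound 2 gives > 1000000 nM, which is a limit of the assay and not a number. In the physicochemical assay compound 3 gives > 1000000 nM, again a limit, so this change leaves the two compounds at the same limit: the limit of > 1000000 nM in the physicochemical assay, at which 2 of the 2 values shown sit.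

Going by these compounds, the step from compound 1 to compound 3 in the Hepatocyte assay and the step from compound 2 to compound 3 in the physicochemical assay cannot be read, because limits stand at both ends of each, as the first of them shows: the limit of < 1 uL/min in the Hepatocyte assay, at which 2 of the 3 values shown sit. How far compound 3 lies past its limit in the Hepatocyte assay stays open, as does how an ethyl or a cyclopropyl group on this aromatic nitrogen would read there.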